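Alkyl variation on the thioether aryl ring

The source may hold more compounds than are shown below. What is called first, only, known or untested is meant among the compounds shown, and "the series" means these compounds.

The measured members of the series are compound 1 `Cc1ccc(SCc2ccc(/C=C/C(=O)Nc3ccccc3N)cc2)cc1`, compound 2 `COc1ccc(SCc2ccc(/C=C/C(=O)Nc3ccccc3N)cc2)cc1OC` and compound 3 `CC(C)(C)c1ccc(SCc2ccc(/C=C/C(=O)Nc3ccccc3N)cc2)cc1`; they differ only in the aryl group on the sulfur. In a functional assay on HCT-116 cells (Homo sapiens) for inhibition, read by CCK-8 assay, with a stated time of 72 h, tested at 2 uM (a higher number here means more inhibition of growth at the concentration tested, a lower number less inhibition of growth), compound 1 gives 6.23%, compound 2 gives 12.9% and compound 3 gives 6.66%. Compound 3 stands second highest of the three numbers. Its nearest neighbour is compound 1, with a number 0.4 percentage points higher from compound 1 to compound 3 (within the scatter), and its furthest is compound 2, with a number 6.2 percentage points lower from compound 2 to compound 3 (within the scatter); between the other two, a number 6.7 percentage points higher from compound 1 to compound 2 (within the scatter). None of the three steps leaves the scatter, so the change of aryl group on the sulfur has not so far separated the compounds.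

Compound 4 `CCc1ccc(SCc2ccc(/C=C/C(=O)Nc3ccccc3N)cc2)cc1` is the unmeasured member. ethyl in place of tert-butyl on an aromatic carbon The step that bears on this change is the one from methyl to tert-butyl at the same place, a number 0.4 percentage points higher from compound 1 to compound 3 (within the scatter), which was within the scatter; ethyl is a third alkyl at that place, and nothing measured suggests that it should behave otherwise. No step beyond the scatter is therefore expected in this assay, in either direction.

Compound 4 is accordingly expected to give 7%, with a range from 0% to 16%. The step this estimate means, a number 0.3 percentage points higher from compound 3 to compound 4 (within the scatter), is expected to lie within the scatter.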

Compound 4, percent growth inhibition at one concentration: 3.29%
Compound 4: the middle estimate sits 3.7 percentage points above what was measured; low and high end bracket the measured number.
By their numbers in this assay, from the lowest: compounds 4, 1, 3 and 2 (each within the scatter of the next).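

In this assay, for the compounds shown here, the change from tert-butyl to ethyl gives a number 3.4 percentage points lower from compound 3 to compound 4 (within the scatter) and the change at the same place from methyl to ethyl gives a number 2.9 percentage points lower from compound 1 to compound 4 (within the scatter) so three alkyl groups of different size now stand at this place, on an aromatic carbon para to a large group, with no step among them beyond the scatter. The largest step yet seen in the series, a number 9.6 percentage points lower from compound 2 to compound 4 (within the scatter) also stays within the scatter, which extends the earlier picture from a single alkyl pair and the 3,4-dimethoxyphenyl comparisons to every pair among the four compounds. Nothing available bears on why the numbers fall where they do.

Going by these compounds, it remains open whether any aryl group on the sulfur can move the growth inhibition at this single concentration beyond the scatter, and a group of another kind at this place, such as an amine, a carboxylic acid or a longer chain, would test that. On these data alone, it also remains open whether the four compounds, which this read-out does not separate, would differ across a range of concentrations.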